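The source may report more compounds than this note shows. Statements on the series, on what has been measured and on what is new or still open speak of the compounds shown alone.

Of the compounds shown here, two that differ in more than one place have been tested in a toxicity assay on THP-1 cells (Homo sapiens) for inhibition; a lower number here means that less compound is tolerated, a higher number that more compound is tolerated. Compound 2 `COc1ccc(-c2cnc(NC(=O)c3ccccc3)n2C)cc1` gives > 100000 nM, which is a limit of the assay and not a number. Compound 1 `Cc1ccccc1-c1cnc(NC(=O)c2ccc(F)cc2)n1C` gives > 50000 nM, and this too is a limit. Neither compound therefore has an exact reading, and the two cannot be ranked against each other.

The next compound to be measured is compound 3 `COc1ccc(-c2cnc(NC(=O)c3ccc(F)cc3)n2C)cc1`. It is compound 2 with a single small change, fluoro in place of hydrogen on an aromatic carbon, which turns a phenyl into a 4-fluorophenyl. Among the compounds with values here, no measured pair of compounds shows what this change does in this assay. The nearest guide is compound 1, which also carries a 4-fluorophenyl group and whose > 50000 nM is likewise a limit. The expected size of the change, a number no higher from compound 2 to compound 3 (the limit leaves the size open), therefore stays within the usual scatter, with no favoured direction. Compound 3 is expected at about 100000 nM, with an estimated range of 50000 nM to 200000 nM, and it may well return only a limit.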

Compound 3, half-maximal cytotoxic concentration: >= 50000 nM
Compound 3 was reported as a limit; the forecaster's own chance of this, stated with the estimate: 85%; the middle value is on the limit's open side.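

Compound 3 returns only a limit in this assay, as do compound 1 and compound 2, so neither the step from compound 2 to compound 3 nor the step from compound 1 to compound 3 can be read. The compounds shown leave open the exact tolerated concentration of all three, and whether fluoro in place of hydrogen changes it at all.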